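Trimming the hydroxyethyl arm: from compound 2 to compound 3

This account rests on a few compounds, and the source may have more. Where it says the series, first, only, none or still open, it means among the compounds named here.

compound 1, `OCCNCc1nc2c(OCC3CCCCC3)cccc2[nH]1`: 63.3%
compound 2, `OCC(NCc1nc2c(OCC3CCCCC3)cccc2[nH]1)c1ccccc1`: 77.7%

In an assay on cells for inhibition of interleukin-5 receptor subunit alpha (Mus musculus), read by WST assay, with a stated time of 48 h, tested at 30 uM, in the presence of a further agent that is not named here (a higher number here means more inhibition at the concentration tested (going by the name of the read-out), a lower number less inhibition), compound 2 holds the highest of the two numbers; its nearest neighbour is compound 1, and the step of a number 14.4 percentage points higher from compound 1 to compound 2 (beyond the scatter) is beyond the scatter. Compound 3, `c1ccc(NCc2nc3c(OCC4CCCCC4)cccc3[nH]2)cc1`, keeps the shared core of compound 2 and changes the amine substituent: phenyl in place of 2-hydroxy-1-phenylethyl on an amine nitrogen. For the measured compounds named here, only one measured step exists, and it bears on the change indirectly: it added a phenyl on a saturated chain carbon and gave a modest gain, whereas here the whole 2-hydroxy-1-phenylethyl group leaves and a phenyl sits directly on the amine nitrogen. Going by the values given here, no measured step shows the loss of the hydroxyl-bearing chain or a phenyl placed on the nitrogen itself. The guidance is therefore weak, and a loss of part of the gain seen in compound 2 is the more cautious expectation. For compound 3 the estimate is 55%, within a range of 30% to 80%. This corresponds to an expected step of a number 22.7 percentage points lower from compound 2 to compound 3 (beyond the scatter).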

Compound 3, a percentage reported as inhibition, at one concentration (the size of the read-out at that concentration, not a potency): 25%
Compound 3: middle estimate off by 30 percentage points, on the high side; measured number outside the range, below it.
By their numbers in this assay, from the lowest: compound 3; then compound 1; then compound 2.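

In this assay, replacing 2-hydroxy-1-phenylethyl with phenyl on the amine nitrogen gives a number 52.7 percentage points lower from compound 2 to compound 3 (beyond the scatter), and replacing 2-hydroxyethyl with phenyl gives a number 38.3 percentage points lower from compound 1 to compound 3 (beyond the scatter). The earlier step showed only a gain when a phenyl was added to the saturated chain; these steps show that a phenyl on the nitrogen itself, with no hydroxyl-bearing chain, does not keep that gain and ends up under compound 1, which has no aromatic ring on this arm. Nothing available gives a cause for this fall.

The compounds shown do not separate the loss of the hydroxyl from the loss of the saturated chain, since the two leave together. A benzyl or 2-phenylethyl group on the amine nitrogen, keeping a chain without the hydroxyl, would bear on that question.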